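Chain shortening on the diene carbon of the PAF antagonist series

This account rests on a few compounds, and the source may have more. Where it says the series, first, only, none or still open, it means among the compounds named here.

Measured compounds:
- compound 1, `CCCCCCCC/C(=C\C=C\C(=O)N[C@H](C)CCCc1cccnc1)c1ccc(OC)cc1`, 0.1 mg/kg
- compound 2, `Cc1ccc(C(=C/C=C/C(=O)N[C@H](C)CCCc2cccnc2)c2ccc(C)cc2)cc1`, 0.3 mg/kg
- compound 3, `COc1ccc(C(=C/C=C/C(=O)N[C@@H](CCCc2cccnc2)C2CC2)c2ccc(OC)cc2)cc1`, 0.2 mg/kg

All three were run in a functional assay with platelet-activating factor receptor (Cavia porcellus) as the target; on this read-out higher numbers stand for an effect only at larger amounts of compound and lower numbers for an effect already at smaller amounts. Compound 1 gives 0.1 mg/kg, the lowest of the three numbers. Compound 3 lies within the scatter of compound 1, so no order between them can be read. Compound 2 gives a number beyond the scatter of compound 1, higher in this assay.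

Among the measured compounds shown here, no pair of measured compounds differs in a single place, so no measured step is available to calibrate the change now considered. The unmeasured compound 4, `CCC/C(=C\C=C\C(=O)N[C@H](C)CCCc1cccnc1)c1ccc(OC)cc1`, differs from compound 1 by hydrogen in place of pentyl on a saturated chain carbon, three bonds along the chain from a double-bonded chain carbon. The other measured compounds carry two aryl groups on that diene carbon rather than an alkyl chain, so they say nothing about chain length at that position.

In this assay the step from compound 1 to compound 4 is expected to be a 3.0-fold higher number from compound 1 to compound 4 (0.48 log units; beyond the scatter), a modest rise in the number, though a result within the scatter cannot be excluded. Compound 4 is estimated at 0.3 mg/kg, with a range from 0.1 mg/kg to 1 mg/kg.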

Compound 4, dose for 50% inhibition: 0.52 mg/kg
The estimate for compound 4 lay 1.7-fold (0.24 log units) below the measured number, and the stated range covers the measured number.
By their numbers in this assay, from the lowest: compounds 1, 3, 2 and 4 (each within the scatter of the next, the first and the last beyond it).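

Octyl to propyl is the only measured step at this position, and in this assay it gives a 5.2-fold higher number from compound 1 to compound 4 (0.72 log units; beyond the scatter). The earlier compounds shown here offered no step to calibrate this change; the new result shows that the length of the alkyl chain on this saturated chain carbon matters, with the step lying beyond the scatter. The part that leaves is pure hydrocarbon, a pentyl of 5 heavy atoms with no ring and no hydrogen-bond donors or acceptors, so a change in the chain alone is enough to shift the number, and nothing available here bears on why it does so.

The compounds shown leave open how the number runs between and beyond these two chain lengths: a butyl or hexyl chain could show whether it climbs gradually or jumps, and a decyl chain whether octyl is already past the best length. Also open, as far as these compounds go, is whether a branched chain, such as isobutyl, or a chain carrying an ether oxygen or a terminal carboxylic acid would be tolerated at this position, and whether the same step would hold with a cyclopropyl group in place of the methyl on the amide side chain.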